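The source may report more compounds than this note shows. Statements on the series, on what has been measured and on what is new or still open speak of the compounds shown alone.

The compounds measured so far:
compound 1, `COc1cc(Oc2cccc(Nc3ccccc3)c2)cc(OC)c1CNCc1ccc(Cl)cc1`: 3740 nM
compound 2, `COc1cc(Oc2cccc(Nc3ccccc3)c2)cc(OC)c1CNC(C)C`: > 20000 nM, a limit of the assay
compound 3, `COc1cc(Oc2cccc(Nc3ccccc3)c2)cc(OC)c1CNCc1ccccc1`: 5220 nM

In a functional assay on DLD-1 cells (Homo sapiens) for inhibition, read by MTT assay, with a stated time of 72 h (a lower number here means a stronger inhibitor, a higher number a weaker inhibitor), compound 1 gives 3740 nM, the lowest of the two plain numbers shown. Compound 3 gives 5220 nM, and the gap is a 1.4-fold higher number from compound 1 to compound 3 (0.14 log units; within the scatter). Compound 2 reaches only > 20000 nM, which is a limit of the assay and not a number (the limit of > 20000 nM in this assay, at which 1 of the 3 values shown sits).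

Compound 4, `COc1cc(Oc2cccc(Nc3ccccc3)c2)cc(OC)c1CN[C@H](C)c1ccccc1`, has not been measured. It differs from compound 1 by 1-phenylethyl in place of 4-chlorobenzyl on an amine nitrogen. For the measured compounds named here, two measured steps bear on this. Taking the chloro off the benzyl ring gave a 1.4-fold higher number from compound 1 to compound 3 (0.14 log units; within the scatter), so the chlorine seems to matter little. Replacing the aromatic group by isopropyl gave an at least 5.3-fold higher number from compound 1 to compound 2 (0.72 log units; beyond the scatter), and going back from isopropyl to benzyl gave an at least 3.8-fold lower number from compound 2 to compound 3 (0.58 log units; beyond the scatter), so an aromatic ring on this amine nitrogen is what keeps the number low. The 1-phenylethyl group keeps one six-membered aromatic ring, so a large loss is not expected; the step from compound 1 to compound 4 in this assay is expected to be small, likely towards a slightly higher number, a 1.6-fold higher number from compound 1 to compound 4 (0.21 log units; within the scatter). Compound 4 is therefore estimated at 6000 nM, with a range from 2500 nM to 15000 nM.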

Compound 4, half-maximal inhibitory concentration: 8570 nM
Compound 4: middle estimate off by 1.4-fold (0.15 log units), on the low side; low and high end bracket the measured number.
By their numbers in this assay, from the lowest: compounds 1, 3 and 4 (each within the scatter of the next, the first and the last beyond it). At a limit, above all of these: compound 2.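

In this assay, a methyl on the saturated chain carbon bound to the amine nitrogen and the aromatic carbon gives a 1.6-fold higher number from compound 3 to compound 4 (0.22 log units; within the scatter), so this carbon accepts that methyl with no difference that can be told from the scatter. The comparison with the 4-chlorobenzyl compound reads differently. It combines the loss of the chloro with the gain of the methyl: a 1.4-fold higher number from compound 1 to compound 3 (0.14 log units; within the scatter) and the methyl step above each stay within the scatter, yet together they amount to a 2.3-fold higher number from compound 1 to compound 4 (0.36 log units; beyond the scatter), which lies beyond it. With the methyl in place, the aromatic ring still keeps the number lower than isopropyl does, an at least 2.3-fold lower number from compound 2 to compound 4 (0.36 log units; beyond the scatter), though that step starts from a limit and not from a number: the limit of > 20000 nM in this assay, at which 1 of the 4 values shown sits.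

From the compounds shown here alone, compound 4 carries one defined stereocentre, so what the mirror-image form of its 1-phenylethyl group would give stays open. Also open, going by these compounds, are a chloro on the ring of the 1-phenylethyl group, and a 2-phenylethyl group, which would place a longer chain between the amine nitrogen and the ring.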